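A few compounds are considered here, and "the series" means these few. Any claim that something is new, unique, unknown or untested is made for them only; others in the source may bear on it.

In a functional assay on MRC5 cells (Homo sapiens) for cytotoxicity (a lower number here means that less compound is tolerated, a higher number that more compound is tolerated), compound 1 (`COC(=O)c1ccc([N+](=O)[O-])o1`) gives > 32000 nM as a limit of the assay, not a number. Within the data shown here, compound 2 (`O=C(Cc1ccccc1)NNC(=O)c1ccc([N+](=O)[O-])o1`) gives 2000 nM as the only actual number so far. Compound 3 (`CC(C)(C)OC(=O)N[C@@H](C(=O)NNC(=O)c1ccc([N+](=O)[O-])o1)c1ccccc1`) has (tert-butoxycarbonyl)amino in place of hydrogen on a saturated chain carbon bound to an aromatic carbon and a carbonyl carbon. Among the measured compounds shown here, no measured step covers this change, so only a small upward shift in this assay is expected (a 2.0-fold higher number from compound 2 to compound 3 (0.30 log units; within the scatter)). The estimated value for compound 3 is 4000 nM (expected range 1000 nM to 20000 nM).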

Compound 3, half-maximal cytotoxic concentration: 6000 nM
Compound 3: the middle estimate sits 1.5-fold (0.18 log units) below what was measured, and the stated range covers the measured number.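

In this assay, the saturated chain carbon bound to an aromatic carbon and a carbonyl carbon takes (tert-butoxycarbonyl)amino in place of hydrogen with a 3.0-fold higher number from compound 2 to compound 3 (0.48 log units; beyond the scatter) as a modest step. A group of 8 heavy atoms at this position therefore shifts the read-out only modestly and still yields an actual number for compound 3. Compound 1 alone stands at a limit, which is not a number: the limit of > 32000 nM in this assay, at which 1 of the 3 values shown sits.

Going by these compounds, whether the shift comes from the whole (tert-butoxycarbonyl)amino group or only from its nitrogen stays open. A free amine or a hydroxyl on the same carbon would separate the two.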